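Working notes: from 4-methoxyphenyl to 4-chlorophenyl

The source may report more compounds than this note shows. Statements on the series, on what has been measured and on what is new or still open speak of the compounds shown alone.

In a functional assay on U-373MG ATCC cells (Homo sapiens) for inhibition, read by MTT assay, with a stated time of 72 h (on this read-out lower numbers stand for stronger inhibition and higher numbers for weaker inhibition), compound 1 (`COc1ccc(NC(=S)NC2CC(C)(C)Oc3ccc(Br)cc32)cc1`) gives 40000 nM. For the measured compounds named here, this is the higher of the only two numbers available. The other comes from compound 2 (`CC1(C)CC(NC(=O)Nc2ccc(Cl)cc2)c2cc(Cl)ccc2O1`), which gives 19000 nM, a gap beyond the usual scatter. These two compounds differ in more than one place, so the gap cannot be assigned to any single change.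

Compound 3 (`CC1(C)CC(NC(=S)Nc2ccc(Cl)cc2)c2cc(Br)ccc2O1`) has not yet been measured. It keeps the core of compound 1 and carries one change: chloro in place of methoxy on an aromatic carbon. This is chloro in place of methoxy on an aromatic carbon, para to a large group, or 4-methoxyphenyl to 4-chlorophenyl when cut one bond further out. Going by the values given here, no measured pair isolates this change. The only, thin, support is compound 2, which also bears the 4-chlorophenyl group and gives 19000 nM. A modest move towards a lower number is therefore expected in this assay, close to the edge of the scatter. The estimated step runs a 1.8-fold lower number from compound 1 to compound 3 (0.26 log units; within the scatter). For compound 3 the expected value is 22000 nM, with an estimated range of 9000 nM to 50000 nM.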

Compound 3, half-maximal inhibitory concentration: 7000 nM
Compound 3: middle estimate off by 3.1-fold (0.50 log units), on the high side; measured number outside the range, below it.
By their numbers in this assay, from the lowest: compound 3; then compound 2; then compound 1.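

With the core of compound 1 held fixed, the change from 4-methoxyphenyl to 4-chlorophenyl now has a step of its own. In this assay the step runs a 5.7-fold lower number from compound 1 to compound 3 (0.76 log units; beyond the scatter) and lies beyond the scatter, so chloro in place of methoxy on an aromatic carbon, para to a large group, is enough by itself to shift the number, something the earlier pair, which differs in more than one place, could not show. Nothing available here accounts for the size of this step, which remains a single observation from one pair.

Open questions remain on how far this position can be pushed: whether fluoro, trifluoromethyl or a dimethylamino group in the same place would give a lower number than chloro or a higher one is not answered by the compounds shown. For the compounds shown here, also open is whether the step carries over to the core of compound 2, since the only pair that isolates this change is built on the core of compound 1.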